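Methyl for fluoro next to the ring nitrogen

The source may report more compounds than this note shows. Statements on the series, on what has been measured and on what is new or still open speak of the compounds shown alone.

Measured compounds:
Compound 1, `O=C(O)CCc1ccc(C#Cc2ccnc(F)c2)cc1`: 513 nM
Compound 2, `Cc1cnc(F)cc1C#Cc1ccc(CCC(=O)O)cc1`: 178 nM
Compound 3, `Cc1c(C#Cc2ccc(CCC(=O)O)cc2)ccnc1F`: 120 nM

In an in vitro functional assay on 1321-N1 cells for agonist activity at Free fatty acid receptor 1 (Homo sapiens), read by fluorescence, spectrophotometry and calcium flux (on this read-out higher numbers stand for an effect only at larger amounts of compound and lower numbers for an effect already at smaller amounts), compound 1 gives the highest of the three numbers; compound 2 and compound 3 both sit below it, with a 2.9-fold lower number from compound 1 to compound 2 (0.46 log units; beyond the scatter) and a 4.3-fold lower number from compound 1 to compound 3 (0.63 log units; beyond the scatter). Compound 4, `Cc1cc(C#Cc2ccc(CCC(=O)O)cc2)ccn1`, is not yet measured. It differs from compound 1 by methyl in place of fluoro on an aromatic carbon. Both measured steps bear on it only in part: each adds a methyl on an aromatic carbon of the shared core while the fluoro stays, and each lowered the number modestly. Among the compounds with values here, no measured step removes the fluoro, so the effect of its loss is unknown. A modest lowering or no change beyond the scatter in this assay is therefore expected, a 1.5-fold lower number from compound 1 to compound 4 (0.17 log units; within the scatter). Compound 4 is estimated at 350 nM, between 120 nM and 1000 nM.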

Compound 4, half-maximal effective concentration: 1120 nM
The estimate for compound 4 lay 3.2-fold (0.51 log units) below the measured number; measured number above the stated range.
By their numbers in this assay, from the lowest: compounds 3 and 2 (each within the scatter of the next); then compound 1; then compound 4.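

In this assay, methyl in place of fluoro on this aromatic carbon, next to the ring nitrogen, moves the number the opposite way from the two methyl additions of compound 2 and compound 3, with a 2.2-fold higher number from compound 1 to compound 4 (0.34 log units; beyond the scatter) as the step. A methyl on this ring therefore does not lower the number wherever it stands, at least not when it takes the place of the fluoro. Nothing measured here accounts for the rise.

From the compounds shown here alone, a hydrogen, a chlorine atom or a methoxy group at this position would separate the loss of the fluoro from the arrival of the methyl, and that remains open. Also open, going by these compounds, is whether the methyl placements of compound 2 and compound 3 would still lower the number without the fluoro.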